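Moving the oxygen along the alkyne side chain

This account rests on a few compounds, and the source may have more. Where it says the series, first, only, none or still open, it means among the compounds named here.

- Compound 1 `Nc1ccc(S(=O)(=O)N2CCN(c3ncc(C(O)(C(F)(F)F)C(F)(F)F)cc3C#CC3CC3)CC2)cn1` gives < 14 mL.min-1.g-1 as a limit of the assay
- Compound 2 `Nc1ccc(S(=O)(=O)N2CCN(c3ncc(C(O)(C(F)(F)F)C(F)(F)F)cc3C#CCO)CC2)cn1` gives < 14 mL.min-1.g-1 as a limit of the assay
- Compound 3 `COCC#Cc1cc(C(O)(C(F)(F)F)C(F)(F)F)cnc1N1CCN(S(=O)(=O)c2ccc(N)nc2)CC1` gives 15 mL.min-1.g-1 as a measured number

Among the compounds with values here, compound 3 holds the only true number in an ADME assay (liver) for metabolic stability, with Liver microsome (Homo sapiens) as the target, using microsomes and NADPH, with a stated time of 30 min, tested at 1 uM (a higher number here means faster removal of the compound, a lower number slower removal), and the rest of the series offers only the limit of < 14 mL.min-1.g-1 in this assay, at which 2 of the 3 values shown sit, here. Compound 4 `Nc1ccc(S(=O)(=O)N2CCN(c3ncc(C(O)(C(F)(F)F)C(F)(F)F)cc3C#CCCO)CC2)cn1` has the same atoms as compound 3, joined differently, with hydroxymethyl in place of methoxy on a saturated chain carbon bound to a triple-bonded carbon and thus hydroxymethyl in place of methoxy on a saturated chain carbon bound to a triple-bonded carbon.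

The closest measured change is methyl in place of hydrogen on an oxygen on a saturated carbon, which gives an at least 1.0-fold higher number from compound 2 to compound 3 (0.02 log units; that floor lies within the scatter) and stays within the scatter. Methoxymethyl in place of cyclopropyl gives an at least 1.0-fold higher number from compound 1 to compound 3 (0.02 log units; that floor lies within the scatter) in the same way, while hydroxymethyl in place of cyclopropyl gives a step that the two limits leave unreadable from compound 1 to compound 2 as its result. No step beyond the scatter is therefore expected, and the estimate is a 1.1-fold lower number from compound 3 to compound 4 (0.03 log units; within the scatter) in this assay for this change. A report as a limit is also quite possible. Compound 4 is expected at 14 mL.min-1.g-1 with an estimated range from 10 mL.min-1.g-1 to 22 mL.min-1.g-1 in this assay.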

Compound 4, intrinsic clearance in microsomes: < 14 mL.min-1.g-1
Compound 4 gave a limit, no number (the forecaster's own chance of this, stated with the estimate: 60%); the middle value lies on the limit itself.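

In this assay, within the data shown here, 4-hydroxybut-1-yn-1-yl in place of 3-methoxyprop-1-yn-1-yl gives an at least 1.0-fold lower number from compound 3 to compound 4 (0.02 log units; that floor lies within the scatter), so this rejoining of the same atoms produces no step that can be read beyond the scatter. The 2-hydroxyethyl group now stands with cyclopropyl and hydroxymethyl on the triple-bonded carbon at the same reported limit, and the steps from compound 1 and from compound 2 to compound 4 cannot be read. Most of the series now gathers at a single boundary of the assay: the limit of < 14 mL.min-1.g-1 in this assay, at which 3 of the 4 values shown sit.

On these data alone, how far compound 1, compound 2 and compound 4 lie from that limit stays open, and so does any order among them. Also open, as far as these compounds go, is what an amine, a carboxylic acid or a longer chain ending in hydroxy on this triple-bonded carbon would give in this assay.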